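Benzyl replaced by 2-chlorophenyl on the shared core

The source may hold more compounds than are shown below. What is called first, only, known or untested is meant among the compounds shown, and "the series" means these compounds.

Compound 1 `COc1ccc(NC(=S)NC2CC(C)(C)Oc3ccc(Br)cc32)cc1` gives 40000 nM in testing
Compound 2 `CC1(C)CC(NC(=S)NCc2ccccc2)c2cc(Br)ccc2O1` gives 29000 nM in testing

Among the compounds with values here, both compounds were tested in a functional assay on U-373MG ATCC cells (Homo sapiens) for inhibition, read by MTT assay, with a stated time of 72 h (a lower number here means a stronger inhibitor, a higher number a weaker inhibitor), and only one measured step joins them, a 1.4-fold lower number from compound 1 to compound 2 (0.14 log units; within the scatter) for benzyl in place of 4-methoxyphenyl on an amide-type nitrogen. Within the data shown here, compound 2 therefore stands level with the only other measured compound. Compound 3 `CC1(C)CC(NC(=S)Nc2ccccc2Cl)c2cc(Br)ccc2O1` differs from compound 2 by 2-chlorophenyl in place of benzyl on an amide-type nitrogen in this same place. Among the measured compounds shown here, the one step at this nitrogen, a 1.4-fold lower number from compound 1 to compound 2 (0.14 log units; within the scatter) stayed within the scatter, so no change beyond the scatter is expected. The expected step is a 1.0-fold higher number from compound 2 to compound 3 (0.01 log units; within the scatter) in this assay by this estimate. Compound 3 is estimated at 30000 nM (expected range 13000 nM to 70000 nM).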

Compound 3, half-maximal inhibitory concentration: 34000 nM
The estimate for compound 3 lay 1.1-fold (0.05 log units) below the measured number, and the stated range covers the measured number.
By their numbers in this assay, from the lowest: compounds 2, 3 and 1 (each within the scatter of the next).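

In this assay, placing 2-chlorophenyl on the amide-type nitrogen in place of benzyl (a 1.2-fold higher number from compound 2 to compound 3 (0.07 log units; within the scatter)) or in place of 4-methoxyphenyl (a 1.2-fold lower number from compound 1 to compound 3 (0.07 log units; within the scatter)) leaves the number inside the scatter. Within the data shown here, a chlorine on the ring, absent from the earlier compounds, thus joins two other ring-bearing groups at this place, and all three read alike. Nothing measured here offers a reason for this sameness.

Still open, from the compounds shown here alone, is whether a group of another kind on this nitrogen, such as a longer alkyl chain or an amine, would shift the number beyond the scatter.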